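Hydroxy for Methoxy on a Second Urea Core

The compounds below may be only part of what the source reports. "The series", "measured", "known", "first", "only" and "open" are said of these compounds alone.

Measured so far in a functional assay on SF-295 cells (Homo sapiens) for inhibition, read by sulforhodamine B assay, with a stated time of 48 h; on this read-out higher numbers stand for lower toxicity in this test and lower numbers for higher toxicity in this test:
- compound 1, `COc1cc(-c2nn(-c3cccc(NC(=O)Nc4cc(C(F)(F)F)cc(C(F)(F)F)c4)c3)cc2-c2ccncc2)ccc1Cl`, gives 3310 nM
- compound 2, `O=C(Nc1cccc(-n2cc(-c3ccncc3)c(-c3ccc(Cl)c(O)c3)n2)c1)Nc1cc(C(F)(F)F)cc(C(F)(F)F)c1`, gives 4390 nM
- compound 3, `COc1cc(-c2nn(-c3cccc(NC(=O)Nc4ccc(Cl)c(C(F)(F)F)c4)c3)cc2-c2ccncc2)ccc1Cl`, gives 14900 nM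

Compound 4, `O=C(Nc1cccc(-n2cc(-c3ccncc3)c(-c3ccc(Cl)c(O)c3)n2)c1)Nc1ccc(Cl)c(C(F)(F)F)c1`, is not yet measured. It differs from compound 3 by hydrogen in place of methyl on an oxygen on an aromatic ring. The same change, (hydrogen in place of methyl on an oxygen on an aromatic ring), links compound 1 to compound 2 and gave a 1.3-fold higher number from compound 1 to compound 2 (0.12 log units; within the scatter). The two place descriptions agree word for word, so this is the same change on two cores; the difference between the core of compound 1 and the core of compound 3 is not broken down here. Compound 3 stands at the highest of the three numbers. Because a 1.3-fold higher number from compound 1 to compound 2 (0.12 log units; within the scatter) was small, the step is expected to be about a 1.2-fold higher number from compound 3 to compound 4 (0.08 log units; within the scatter). Compound 4 is therefore estimated at 18000 nM, with a likely range from 8000 nM to 40000 nM.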

Compound 4, concentration lethal to 50% of the cells: > 32500 nM
Compound 4: no number, only a limit (the forecaster's own chance of this, stated with the estimate: 15%); middle value at least 1.8-fold (0.25 log units) away from the limit.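

In this assay, compound 4 gives > 32500 nM, which is a limit of the assay and not a number. Replacing methoxy with hydroxy gives an at least 2.1-fold higher number from compound 3 to compound 4 (0.33 log units; beyond the scatter), whereas the same change on the other core gives a 1.3-fold higher number from compound 1 to compound 2 (0.12 log units; within the scatter). This does not show whether the change carries over from one core to the other with the same size of step: the same change on two cores in this assay, a 1.3-fold higher number (0.12 log units; within the scatter) from compound 1 to compound 2 and an at least 2.1-fold higher number (0.33 log units; beyond the scatter) from compound 3 to compound 4; the limit leaves it open whether they differ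

The compounds shown leave open the actual number for compound 4, and with it the full size of its step. They also leave open what an amine or an ethoxy group in the place of the hydroxy would give on either core.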